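The source may report more compounds than this note shows. Statements on the series, on what has been measured and on what is new or still open speak of the compounds shown alone.

Measured in an ADME assay on HepG2 cells (Homo sapiens) for cytotoxicity, with a stated time of 72 h; on this read-out lower numbers stand for an effect already at smaller amounts and higher numbers for an effect only at larger amounts of compound:

- Compound 1 `Cc1ccc(-c2nc3ccccc3s2)cc1NC(=O)c1cc([N+](=O)[O-])c(N(C)C)cc1Cl`: > 25000 nM
- Compound 2 `O=C(Nc1cccc(-c2nc3ccccc3s2)c1)c1cc([N+](=O)[O-])c(O)cc1Cl`: > 25000 nM
- Compound 3 `O=C(Nc1nc(-c2ccc(Cl)cc2)cs1)c1cc([N+](=O)[O-])ccc1Cl`: > 27000 nM

None of these three results is an exact number. Compound 2 stands at > 25000 nM, which is a limit of the assay.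

Compound 4 `O=C(Nc1cccc(-c2nc3ccccc3s2)c1)c1cc([N+](=O)[O-])ccc1Cl` has hydrogen in place of hydroxy on an aromatic carbon. Within the data shown here, no pair of measured compounds shows directly what this change does in this assay. Compound 3 also carries no hydroxy and gives > 27000 nM, again a limit. No change beyond the usual scatter is therefore expected, and the estimated a number no higher from compound 2 to compound 4 (the limit leaves the size open) reflects this. For compound 4 the expected value is 25000 nM, with an estimated range from 10000 nM to 50000 nM.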

Compound 4, half-maximal effective concentration: > 27000 nM
Compound 4: a limit, no number; the forecaster's own chance of this, stated with the estimate: 75%; middle value at least 1.0-fold (0.03 log units) away from the limit.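

In this assay compound 4 gives > 27000 nM, which is a limit. Among these compounds, compound 2 also gives only a limit, so no step between compound 2 and compound 4 can be read. The compounds shown leave open whether replacing hydroxy with hydrogen changes cytotoxicity at all.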